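Turning the Ring Stereocentres: Compound 2 to Compound 4

The source may hold more compounds than are shown below. What is called first, only, known or untested is meant among the compounds shown, and "the series" means these compounds.

Compound 1: `NC(=O)CNCc1ccc(OCc2ccccc2F)cc1`; an assay on HEK293 cells for inhibition of sodium channel protein type 3 subunit alpha (Homo sapiens), read by electrophysiology, with a stated time of 3.5 min; on this read-out higher numbers stand for weaker inhibition and lower numbers for stronger inhibition: 50100 nM
Compound 2: `NC(=O)[C@H]1CCC[C@@H](c2ccc(OCc3cccc(F)c3)cc2)N1`; this assay: 39800 nM
Compound 3: `C[C@@H](C(N)=O)N1CCc2cc(OCc3ccccc3F)ccc2C1`; this assay: > 79400 nM

Three compounds carry the same amide and fluorobenzyloxy-phenyl motifs on different cores, and all of them inhibit the channel only weakly in this assay. For compound 3 the result is a limit of the assay rather than a number, (the limit of > 79400 nM in this assay, at which 1 of the 3 values shown sits). Among the two numbers given, compound 2 has the lowest, and the value of compound 1 sits within the scatter of it, so the two cannot be told apart.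

Compound 4 is `NC(=O)[C@@H]1CCC[C@H](c2ccc(OCc3cccc(F)c3)cc2)N1`. Compared with compound 2 it shows (the two compounds have the same atoms and bonds and differ only in configuration as drawn: 2 of 2 stereo elements differ (all stereocentres are inverted: mirror images); a stereocentre at a saturated ring carbon is drawn R in compound 2 and S in compound 4; a stereocentre at a saturated ring carbon is drawn S in compound 2 and R in compound 4). Among the measured compounds shown here, no measured pair in this set separates two such mirror images, so there is nothing here to say how large a change this configuration swap brings, or in which direction. Because compound 2 is already at 39800 nM, a weak value, the expectation for compound 4 is a weak value of similar size. The step from compound 2 to compound 4 is expected to be a 1.3-fold higher number from compound 2 to compound 4 (0.10 log units; within the scatter). Compound 4 is therefore estimated at 50000 nM, between 15000 nM and 120000 nM.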

Compound 4, half-maximal inhibitory concentration: 39800 nM
For compound 4 the middle estimate is 1.3-fold (0.10 log units) above the measured one; low and high end bracket the measured number.
By their numbers in this assay, from the lowest: compounds 2, 4 and 1 (each within the scatter of the next). At a limit, above all of these: compound 3.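

In this assay, among the compounds shown here, inverting both ring stereocentres brings no change at the digits printed from compound 2 to compound 4 (within the scatter), and this is the first comparison in the set in which only one kind of change is in play. Compounds 1 and 3 each differ from compound 2 in their core, so they could say nothing about configuration, whereas this pair isolates it completely: the fact that compounds 2 and 4 differ only in the configuration as drawn. At this level of weak inhibition, then, the assay does not tell the two mirror-image arrangements of the ring apart, and the configuration as drawn offers no handle on the result in either direction.

As far as these compounds go, what each stereocentre does on its own stays open, as the pair inverts both together and says nothing about a form with only one of them inverted. Also open, from the compounds shown here alone, is whether this indifference to configuration would hold on a compound with stronger inhibition, for instance one that carries a carboxylic acid or an amine in place of the amide on the same core.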